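Halogen swap on the aryl ring: chloro to bromo

This account rests on a few compounds, and the source may have more. Where it says the series, first, only, none or still open, it means among the compounds named here.

Measured so far:
compound 1, `CC(=O)N1N=C(c2ccc(F)cc2)CC1c1cn(-c2ccccc2)nc1-c1ccc(F)cc1`: 43%
compound 2, `CC(=O)N1N=C(c2ccc(F)cc2)CC1c1cn(-c2ccccc2)nc1-c1ccc(Cl)cc1`: 44%

In a functional assay on the whole organism (Tail) with Rattus norvegicus as the target, in the tail flick test, with a stated time of 60 min, at a dose of 25 mg/kg by the oral route (a higher number here means more inhibition at the dose given (going by the name of the read-out), a lower number less inhibition), compound 1 gives 43% and compound 2 gives 44%. Within the data shown here, the two numbers sit within the scatter of each other; the only step measured, a number 1 percentage points higher from compound 1 to compound 2 (within the scatter), carries no sign of a real change, so compound 2 can be placed level with compound 1 and nowhere else.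

Compound 3, `CC(=O)N1N=C(c2ccc(F)cc2)CC1c1cn(-c2ccccc2)nc1-c1ccc(Br)cc1`, is not yet measured. Its change from compound 2 is bromo in place of chloro on an aromatic carbon, at the same aromatic carbon where compound 2 differs from compound 1, reading 4-chlorophenyl to 4-bromophenyl. Among the measured compounds shown here, the one step that bears on it is a number 1 percentage points higher from compound 1 to compound 2 (within the scatter), which stayed within the scatter. On that single precedent, compound 3 is expected to give a step of no change at the digits printed from compound 2 to compound 3 (within the scatter), that is, nothing beyond the scatter. The estimate for compound 3 is 44%, with a range from 33% to 55%.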

Compound 3, a percentage reported as inhibition, in the whole organism at one dose (the size of the read-out at that dose, not a potency): 71%
Estimate against measurement, compound 3: 27 percentage points below; measured number outside the range, above it.
By their numbers in this assay, from the lowest: compounds 1 and 2 (each within the scatter of the next); then compound 3.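

The halogen on this aromatic carbon, para to a large group, matters in this assay after all: bromo in place of chloro gives a number 27 percentage points higher from compound 2 to compound 3 (beyond the scatter) and bromo in place of fluoro gives a number 28 percentage points higher from compound 1 to compound 3 (beyond the scatter) while chloro in place of fluoro gave only a number 1 percentage points higher from compound 1 to compound 2 (within the scatter). Across these three compounds the read-out therefore does not move evenly with the halogen, as fluoro and chloro stand level and bromo alone stands apart. Nothing at hand bears on what lies behind the bromo result.

From the compounds shown here alone, whether this belongs to bromo alone remains open, and iodo, methyl or methoxy on the same aromatic carbon would help to settle it. Also open, going by these compounds, is whether bromo in place of fluoro on the other 4-fluorophenyl group of the shared core would give a similar step.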